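Isopropyl for Propyl, Repeated on a Second Core

The source may hold more compounds than are shown below. What is called first, only, known or untested is meant among the compounds shown, and "the series" means these compounds.

Measured compounds:
compound 1, `CCCC(=O)c1ccc(OCCCCOc2cc(C(=O)O)ccc2OC)c(C)c1O`, gives 82.8%
compound 2, `COc1ccc(C(=O)O)cc1OCCCCOc1ccc(C(=O)C(C)C)c(O)c1C`, gives 66.6%
compound 3, `CCCC(=O)c1ccc(OCCCCOc2ccc(C(=O)O)cc2C)c(C)c1O`, gives 79.3%

In an assay on HEK293 cells for positive allosteric modulation of metabotropic glutamate receptor 2 (Rattus norvegicus), read by thallium flux, with a stated time of 2.5 min (on this read-out higher numbers stand for larger maximal responses and lower numbers for smaller maximal responses), the three measured compounds spread modestly. Compound 1 and compound 3 differ in their cores, and the difference between the two cores is not broken down here; their values lie within the scatter of each other, while compound 2 lies beyond the scatter below both. For the measured compounds named here, the one counted change, (isopropyl in place of propyl on a carbonyl carbon), gave a number 16.2 percentage points lower from compound 1 to compound 2 (beyond the scatter).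

Compound 4, `Cc1cc(C(=O)O)ccc1OCCCCOc1ccc(C(=O)C(C)C)c(O)c1C`, carries the same change on the core of compound 3: isopropyl in place of propyl on a carbonyl carbon. Because the earlier step was a number 16.2 percentage points lower from compound 1 to compound 2 (beyond the scatter), a step of comparable size is expected from compound 3, namely a number 16.3 percentage points lower from compound 3 to compound 4 (beyond the scatter). Compound 4 is therefore estimated at 63%, with a likely range from 50% to 76%.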

Compound 4, largest response reached (reported as percent of maximum), in percent of the reference or control that the assay uses: 76.9%
The estimate for compound 4 lay 13.9 percentage points below the measured number; the whole stated range lies below it.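

On the core of compound 3, isopropyl in place of propyl on a carbonyl carbon gave a number 2.4 percentage points lower from compound 3 to compound 4 (within the scatter) in this assay. Set beside the step on the other core, the two readings cannot be told apart: the same change on two cores in this assay, a number 16.2 percentage points lower (beyond the scatter) from compound 1 to compound 2 and a number 2.4 percentage points lower (within the scatter) from compound 3 to compound 4, 13.8 percentage points apart, within the scatter of two such steps

The change thus did not clearly repeat the drop seen on the core of compound 1, yet these two pairs do not show that the core alters its effect, nor do they give a rule for other cores in this series.

The compounds shown leave open what a cyclopropyl or a tert-butyl on that carbonyl carbon would give. They also leave open whether the picture would hold with a tetrazole in place of the carboxylic acid.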